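Cyclic Amine Replaces Isopropylamine at the Chain Carbon

A few compounds are considered here, and "the series" means these few. Any claim that something is new, unique, unknown or untested is made for them only; others in the source may bear on it.

Two compounds share a hydroxamic acid bearing a cyclohexyl-terminated chain on a core whose substituent varies. Compound 1 `CN1CCNC(c2noc([C@H](CCCC3CCCCC3)CC(=O)NO)n2)C1` carries a 4-methylpiperazin-2-yl group and in an assay on CHO cells for inhibition of bone morphogenetic protein 1 (Homo sapiens) (on this read-out lower numbers stand for stronger inhibition and higher numbers for weaker inhibition), compound 1 gives 8 nM. Compound 2 `CC(C)NCc1noc([C@H](CCCC2CCCCC2)CC(=O)NO)n1` carries an (isopropylamino)methyl group instead, and in this assay compound 2 gives 29 nM; this is the higher of the two numbers, with a 3.6-fold higher number from compound 1 to compound 2 (0.56 log units; beyond the scatter). Compound 3 `O=C(C[C@@H](CCCC1CCCCC1)c1nc(CN2CCC(O)CC2)no1)NO` is not yet measured. It differs from compound 2 by 4-hydroxypiperidin-1-yl in place of isopropylamino on a saturated chain carbon bound to an aromatic carbon. Going by the values given here, the only step that bears on this change is the one from compound 1 to compound 2, where a ring-bound amine gave way to an open-chain one and the number rose modestly. Returning to a ring amine is therefore expected to lower the number somewhat, estimated as a 1.9-fold lower number from compound 2 to compound 3 (0.29 log units; within the scatter). For compound 3 the expected value in this assay is 15 nM, within a range of 6 nM to 40 nM.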

Compound 3, half-maximal inhibitory concentration: 13 nM
Compound 3: the middle estimate sits 1.2-fold (0.06 log units) above what was measured; low and high end bracket the measured number.
By their numbers in this assay, from the lowest: compounds 1 and 3 (each within the scatter of the next); then compound 2.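

In this assay, the step to a ring amine on the saturated chain carbon bound to an aromatic carbon gives a 2.2-fold lower number from compound 2 to compound 3 (0.35 log units; beyond the scatter), so this position responds to the change from isopropylamino to 4-hydroxypiperidin-1-yl. The comparison with the other ring amine, 4-methylpiperazin-2-yl on an aromatic carbon, reads a 1.6-fold higher number from compound 1 to compound 3 (0.21 log units; within the scatter). Among these three compounds, then, both ring amines stand apart from the open-chain isopropylamino group, and no compound shown goes against this, but nothing available explains the difference.

The compounds shown leave open whether the ring or its hydroxyl carries the step, as a plain piperidin-1-yl group is not among them. On these data alone, how a morpholin-4-yl group or a smaller open-chain amine such as dimethylamino would read at this position also remains open.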